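The compounds below may be only part of what the source reports. "The series", "measured", "known", "first", "only" and "open" are said of these compounds alone.

Compound 1 `CN(C)CCn1cnnc1-c1cc(Oc2ccc(NC(=O)N/N=C/c3ccc(F)cc3)cc2F)ccn1` is the starting point of this small series. In a functional assay on U-87MG ATCC cells (Homo sapiens) for cytotoxicity, read by MTT assay, with a stated time of 72 h (a lower number here means a stronger inhibitor, a higher number a weaker inhibitor), compound 1 gives 2310 nM. Compound 2 `CN(C)CCn1cnnc1-c1cc(Oc2ccc(NC(=O)N/N=C/c3ccc(F)cc3F)cc2F)ccn1` differs from it by fluoro in place of hydrogen on an aromatic carbon, and in this assay compound 2 gives 1900 nM; the step of a 1.2-fold lower number from compound 1 to compound 2 (0.08 log units; within the scatter). Compound 3 `CN(C)CCn1cnnc1-c1cc(Oc2ccc(NC(=O)N/N=C/c3ccc(O)cc3)cc2F)ccn1` carries a different core, which differs from that of compound 1 by hydroxy in place of fluoro on an aromatic carbon. In this assay compound 3 gives 7750 nM, so that a 3.4-fold higher number from compound 1 to compound 3 (0.53 log units; beyond the scatter) and, from the other measured neighbour, a 4.1-fold higher number from compound 2 to compound 3 (0.61 log units; beyond the scatter). Among the three measured compounds, compound 3 thus stands with the highest number.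

Compound 4 `CN(C)CCn1cnnc1-c1cc(Oc2ccc(NC(=O)N/N=C/c3ccc(O)c(F)c3)cc2F)ccn1` has not yet been measured. It differs from compound 3 by fluoro in place of hydrogen on an aromatic carbon. This is the same kind of change that turned compound 1 into compound 2, but the surroundings are not the same: in compound 2 the fluoro entered ortho to a large group and meta to a fluoro group, whereas in compound 4 it enters ortho to a hydroxy group and meta to a large group. Among the measured compounds shown here, the only measured guide is the step from compound 1 to compound 2, which fell within the scatter. On that basis the expected step of a 1.2-fold lower number from compound 3 to compound 4 (0.08 log units; within the scatter) is small, with no reason from the data to foresee a large move in either direction. Compound 4 is therefore estimated at 6500 nM, with a plausible range from 3000 nM to 14000 nM.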

Compound 4, half-maximal inhibitory concentration: > 100000 nM
Compound 4 was reported as a limit; the forecaster's own chance of this, stated with the estimate: 5%; middle value at least 15-fold (1.18 log units) from the limit.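

Compound 4 is reported in this assay only as a limit, > 100000 nM, and not as a number. The steps that reach it can therefore be read only as minimum sizes: an at least 12-fold higher number from compound 3 to compound 4 (1.11 log units; beyond the scatter), alongside an at least 52-fold higher number from compound 2 to compound 4 (1.72 log units; beyond the scatter) and an at least 43-fold higher number from compound 1 to compound 4 (1.63 log units; beyond the scatter). Fluoro in place of hydrogen on an aromatic carbon thus did not carry over from one core to the other with the same outcome, although this rests on a single pair of steps, the fluoro does not enter the same place in the two cases, and the comparison neither gives a reason for the difference nor tells how far the true figure for compound 4 lies past the limit: the same change on two cores in this assay, a 1.2-fold lower number (0.08 log units; within the scatter) from compound 1 to compound 2 and an at least 12-fold higher number (1.11 log units; beyond the scatter) from compound 3 to compound 4, at least 15-fold (1.19 log units) apart, beyond the scatter of two such steps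

The compounds shown leave open whether the large step belongs to fluoro alone or to fluoro together with the hydroxy group, and whether chloro or methyl in the same place would behave alike. Equally open, as far as these compounds go, is whether methoxy, an amine or a carboxylic acid in place of that hydroxy group would give a measurable number in this assay.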